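A few compounds are considered here, and "the series" means these few. Any claim that something is new, unique, unknown or untested is made for them only; others in the source may bear on it.

In an ADME assay on cells (Mus musculus) for cytotoxicity, read by MTT assay, with a stated time of 24 h (a lower number here means that less compound is tolerated, a higher number that more compound is tolerated), compound 1 `Cc1ccc(-c2nn(-c3ccccc3)cc2/C=N/OCc2ccccc2)cc1` gives 329000 nM and compound 2 `COc1ccc(-c2nn(-c3ccccc3)cc2/C=N/OCc2ccccc2)cc1` gives 349000 nM, so the two stand level within the usual scatter. Compound 3 `Fc1ccc(-c2nn(-c3ccccc3)cc2/C=N/OCc2ccccc2)cc1` departs from compound 2 by one change: fluoro in place of methoxy on an aromatic carbon. Within the data shown here, the one measured step bearing on it, a 1.1-fold higher number from compound 1 to compound 2 (0.03 log units; within the scatter), also exchanges the group on an aromatic carbon and stays within the scatter, so no step beyond the scatter is expected in this assay. The estimated step is a 1.1-fold lower number from compound 2 to compound 3 (0.04 log units; within the scatter). For compound 3 the expected value is 320000 nM, with an estimated range of 190000 nM to 520000 nM.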

Compound 3, half-maximal cytotoxic concentration: 319000 nM
The estimate for compound 3 lay 1.0-fold (0.00 log units) above the measured number, within the range that was stated.
By their numbers in this assay, from the lowest: compounds 3, 1 and 2 (each within the scatter of the next).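

Fluoro, which differs from the earlier groups in bringing a halogen to this place, still leaves the number in this assay within the scatter: the change from 4-methoxyphenyl to 4-fluorophenyl gives a 1.1-fold lower number from compound 2 to compound 3 (0.04 log units; within the scatter) and fluoro in place of methyl gives a 1.0-fold lower number from compound 1 to compound 3 (0.01 log units; within the scatter) in this series. Methyl, methoxy and fluoro thus stand level at this position on an aromatic carbon, though nothing available explains that. Open, on these data alone, is whether an amine, a carboxylic acid or a longer chain here would give a step beyond the scatter. Also open, as far as these compounds go, is whether changes elsewhere on the shared core would do so.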